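Exchanging a sulfonamide linker for an extended amide

The source may report more compounds than this note shows. Statements on the series, on what has been measured and on what is new or still open speak of the compounds shown alone.

Among the measured compounds shown here, compound 2 `O=S(=O)(NCCNc1nccc(-c2c(-c3cccc(F)c3)nc3sccn23)n1)c1cccc(F)c1` gives 14900 nM in a functional assay on A-375 cells (Homo sapiens) for cytotoxicity, read by MTT assay (a lower number here means a stronger inhibitor, a higher number a weaker inhibitor), the higher of the two numbers so far, with compound 1 `O=S(=O)(NCCNc1nccc(-c2c(-c3cccc(F)c3)nc3sccn23)n1)c1ccc(Br)cc1` close by at 13500 nM. For the measured compounds named here, the only measured step, a 1.1-fold higher number from compound 1 to compound 2 (0.04 log units; within the scatter), swaps one aryl group on the sulfonyl sulfur for another and stays within the scatter. Compound 3 `O=C(NCCCNc1nccc(-c2c(-c3cccc(F)c3)nc3sccn23)n1)c1ccc(Cl)cc1` differs from compound 2 by (((4-chlorophenyl)carbonyl)amino)methyl in place of ((3-fluorophenyl)sulfonyl)amino on a saturated chain carbon, two bonds along the chain from a nitrogen on an aromatic ring. Going by the values given here, that change touches the linker itself, not just the aryl group, and no measured step speaks to it; the one step that exists, from compound 1 to compound 2, shows that the aryl group on the linker moved the number little. With nothing pointing either way, the expected step of a 1.1-fold lower number from compound 2 to compound 3 (0.06 log units; within the scatter) in this assay is no change beyond the scatter, held loosely. Compound 3 is therefore estimated at 13000 nM, with a range from 4000 nM to 40000 nM.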

Compound 3, half-maximal inhibitory concentration: 13700 nM
Compound 3: the middle estimate sits 1.1-fold (0.02 log units) below what was measured; the range from low to high includes it.
By their numbers in this assay, from the lowest: compounds 1, 3 and 2 (each within the scatter of the next).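

Replacing ((3-fluorophenyl)sulfonyl)amino with (((4-chlorophenyl)carbonyl)amino)methyl alters the linker itself and not only the aryl group at its end, yet this assay records a 1.1-fold lower number from compound 2 to compound 3 (0.04 log units; within the scatter) for this swap. The same swap made on the 4-bromophenyl compound gives a 1.0-fold higher number from compound 1 to compound 3 (0.01 log units; within the scatter) in this assay as well, so among these three compounds neither the sulfonyl or carbonyl linker nor the aryl group separates the numbers. No measurement is available that would explain this result.

As far as these compounds go, this swap alters the linking group, the chain and the aryl group all at once, so the share of each remains unknown, and opposing contributions cannot be ruled out. Also open, from the compounds shown here alone, is how the number would respond to an amine or a carboxylic acid in place of the aryl group, or to a longer chain.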